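The compounds below may be only part of what the source reports. "The series", "measured", "known", "first", "only" and "open" are said of these compounds alone.

Compound 1 `N/C(=N\NC(=S)N1CCSCC1)c1ccccn1` gives 7800 nM in a functional assay on HeLa cells (Homo sapiens) for cytotoxicity, read by MTT assay, with a stated time of 72 h; on this read-out higher numbers stand for weaker inhibition and lower numbers for stronger inhibition. Compound 2 `Cc1cccc(/C(N)=N/NC(=S)N2CCCC2)n1` gives 2700 nM.

Of these two numbers, compound 2 has the lowest; its nearest neighbour is compound 1, whose number is higher by a margin beyond the usual scatter. Compound 1 and compound 2 differ in more than one place, so no single change can be read from them. Compound 3 `N/C(=N\NC(=S)N1CCCC1)c1ccccn1` differs from compound 2 in one place: hydrogen in place of methyl on an aromatic carbon. Among the measured compounds shown here, no measured pair isolates this change, so in this assay only a modest step is expected, in either direction, perhaps none beyond the scatter. For compound 3 the estimate is 4000 nM, ranging from 1500 nM to 12000 nM. The expected step is then a 1.5-fold higher number from compound 2 to compound 3 (0.17 log units; within the scatter).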

Compound 3, half-maximal inhibitory concentration: 6200 nM
Compound 3: middle estimate off by 1.6-fold (0.19 log units), on the low side; measured number inside the range.
By their numbers in this assay, from the lowest: compound 2; then compounds 3 and 1 (each within the scatter of the next).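

Hydrogen in place of methyl on the aromatic carbon next to the ring nitrogen gives a 2.3-fold higher number from compound 2 to compound 3 (0.36 log units; beyond the scatter) in this assay and shows that a change at this position can move the number, with the methyl on the side of stronger inhibition. Pyrrolidin-1-yl in place of thiomorpholin-4-yl on the thiocarbonyl carbon gives a 1.3-fold lower number from compound 1 to compound 3 (0.10 log units; within the scatter) and so shows no difference that can be claimed. Nothing at hand gives a reason for the methyl step. Going by these compounds, whether an ethyl group, a chlorine atom or a methoxy group on this carbon would give a lower or a higher number stays open.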